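A Fluorinated Cyclopropyl Ring Replaces an Ethyl Chain

The source may hold more compounds than are shown below. What is called first, only, known or untested is meant among the compounds shown, and "the series" means these compounds.

Three compounds have been measured in an assay on SH-EP1 cells for agonist activity at Neuronal acetylcholine receptor; alpha4/beta2 (Homo sapiens), read by FLIPR and calcium flux; a higher number here means a larger maximal response, a lower number a smaller maximal response:

compound 1, `CCC(=O)N1CC2CC(C1)N2`: 110%
compound 2, `CCCC(=O)N1CC2CC(C1)N2`: 110%
compound 3, `O=C(C1CC=CC1)N1CC2CC(C1)N2`: 95%

In this assay compound 1 stands level with compound 2 at the digits shown, and the two together give the highest of the three numbers; compound 3 gives a number lower than compound 1, beyond the scatter. Going by the values given here, the only step that changes a single place, no change at the digits printed from compound 1 to compound 2 (within the scatter), puts a methyl in place of hydrogen on a saturated chain carbon two bonds along the chain from a carbonyl carbon and leaves the response unchanged within the scatter.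

Compound 4 `O=C([C@@H]1C[C@@H]1F)N1CC2CC(C1)N2` differs from compound 1 in that (2-fluorocyclopropyl in place of ethyl on a carbonyl carbon). Among the compounds with values here, no measured step matches this exchange: the step of no change at the digits printed from compound 1 to compound 2 (within the scatter) concerns a chain that grows, not a ring that enters, and no step between compound 1 and compound 3 is computed, so only their two values can be set side by side. Compound 3, whose carbonyl also carries a ring, gives 95% where compound 1 gives 110%. The response of compound 4 is therefore expected to sit near that of compound 1, somewhat lower if anything, so that the step of a number 10 percentage points lower from compound 1 to compound 4 (within the scatter) is estimated to fall within or just beyond the scatter, downward. Compound 4 is expected to give 100% in this assay, with a range from 80% to 115%.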

Compound 4, largest response reached (Emax), in percent of the reference or control that the assay uses: 110%
Beside the measured number, compound 4's estimate is 10 percentage points below it; measured number inside the range.
By their numbers in this assay, from the lowest: compound 3; then compounds 1, 2 and 4 (each within the scatter of the next).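

In this assay, the carbonyl carbon whose other neighbours are an amide-type nitrogen in a ring takes a 2-fluorocyclopropyl group in place of ethyl, and the result is no change at the digits printed from compound 1 to compound 4 (within the scatter); in place of propyl, the result is no change at the digits printed from compound 2 to compound 4 (within the scatter). The earlier step at this position involved only a growing saturated chain, whereas this exchange brings in a three-membered ring, a fluorine and two defined stereocentres, and the maximal response still stays level with both chain compounds, so the lower number of compound 3, 95%, does not extend to every ring at this position. No evidence is available to explain why the response holds across this change.

The compounds shown leave open whether the fluorine or the ring matters here, since plain cyclopropyl does not appear among them, and whether the opposite arrangement of the two stereocentres would give the same response. They also leave open how far the position tolerates larger groups, such as cyclohexyl, phenyl or a longer chain like hexyl.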